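The source may report more compounds than this note shows. Statements on the series, on what has been measured and on what is new or still open speak of the compounds shown alone.

Compound 3 `CC(C)N1C(=O)C(=O)N=C1/N=C(\NCC(C)(C)C)Nc1ccc(Cl)c(Cl)c1` is measured only to a limit in an in vitro ADME assay on microsomes from liver (Mus musculus) for metabolic stability, read by LC-MS; a lower number here means that the compound disappears faster, a higher number that the compound lasts longer: compound 3 gives > 1 h, which is a limit of the assay and not a number. Compound 1 `CCON/C(=N\C1=NC(=O)C(=O)N1C(C)C)Nc1ccc(Cl)c(Cl)c1` gives > 1 h in this assay, again a limit. Compound 2 `CC(C)N1C(=O)C(=O)N=C1/N=C(/Nc1ccc(Cl)c(Cl)c1)NC(C)(C)C` gives > 1 h in this assay, also a limit. The steps a step that the two limits leave unreadable from compound 1 to compound 3, a step that the two limits leave unreadable from compound 2 to compound 3 and a step that the two limits leave unreadable from compound 1 to compound 2 therefore cannot be read, and the only common ground is the limit of > 1 h in this assay, at which 3 of the 3 values shown sit. Compound 4 `CC(C)N1C(=O)C(=O)N=C1/N=C(\NCc1ccccc1)Nc1ccc(Cl)c(Cl)c1` carries the change (phenyl in place of tert-butyl on a saturated chain carbon bound to an amine nitrogen). Within the data shown here, no measured step bears on this exchange, so the size of a number no higher from compound 3 to compound 4 (the limit leaves the size open) is expected to remain unknown. Compound 4 is expected to give 1 h in this assay, within 0.3 h to 3 h.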

Compound 4, half-life: > 1 h
Compound 4: a limit, no number; the forecaster's own chance of this, stated with the estimate: 45%; the middle value sits exactly at the limit.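

In this assay compound 4 gives > 1 h, a limit and not a number. Among these compounds, no step from compound 1, compound 2 or compound 3 to compound 4 can be read. The compounds shown leave open how the ethoxy, tert-butyl, neopentyl and benzyl compounds rank in half-life, with all values at one limit: the limit of > 1 h in this assay, at which 4 of the 4 values shown sit.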